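The compounds below may be only part of what the source reports. "The series", "measured", "known", "first", "only" and "open" are said of these compounds alone.

Working notes on the series. Compound 1 `N#Cc1ccc2[nH]cc(C3=CCC(NCc4ccccc4)CC3)c2c1` and compound 3 `N#Cc1ccc2[nH]cc(C3=CCC(N4CCCCC4)CC3)c2c1` carry an unsaturated ring; compound 2 `N#Cc1ccc2[nH]cc([C@H]3CC[C@@H](NCc4ccccc4)CC3)c2c1` and compound 4 `N#Cc1ccc2[nH]cc([C@H]3CC[C@@H](N4CCCCC4)CC3)c2c1` carry the saturated counterpart. The difference between the two cores is not broken down here. In an assay on cell membranes for binding affinity to Adrenergic receptor alpha-1 (Rattus norvegicus), tested at 1 uM (on this read-out higher numbers stand for more inhibition at the one concentration tested (going by the name of the read-out) and lower numbers for less inhibition), compound 1 gives 27%, compound 2 gives 17% and compound 3 gives 10%. The change from compound 1 to compound 3 is piperidin-1-yl in place of benzylamino on a saturated ring carbon, and it brings a number 17 percentage points lower from compound 1 to compound 3 (beyond the scatter). The same change, (piperidin-1-yl in place of benzylamino on a saturated ring carbon), leads from compound 2 to compound 4; it occurs twice among these compounds. Since compound 2 sits at 17%, a step of the same size is expected to give a number 12 percentage points lower from compound 2 to compound 4 (beyond the scatter), resting on the step from compound 1 to compound 3 only. Compound 4 is therefore estimated at 5%, between -5% and 15% in this assay.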

Compound 4, a percentage reported as inhibition, at one concentration (the size of the read-out at that concentration, not a potency): 3%
Beside the measured number, compound 4's estimate is 2 percentage points above it; the measured number falls inside the stated range.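

In this assay, piperidin-1-yl in place of benzylamino on a saturated ring carbon brings a number 14 percentage points lower from compound 2 to compound 4 (beyond the scatter), and the change carries over between the two cores with a step of similar size: the same change on two cores in this assay, a number 17 percentage points lower (beyond the scatter) from compound 1 to compound 3 and a number 14 percentage points lower (beyond the scatter) from compound 2 to compound 4, 3 percentage points apart, within the scatter of two such steps. This rests on two pairs only, one on the unsaturated core and one on the saturated core, so it does not show that the step would hold on any other core. It also does not separate the loss of the aromatic ring from the loss of the hydrogen-bond donor, and single-concentration percentages give no potency.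

Open, from the compounds shown here alone, is how other amines at this ring carbon would read, such as morpholine or dimethylamino. Also open, going by these compounds, is whether the step holds with a carboxylic acid in place of the nitrile.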